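Bringing the ring hydroxyl back in compound 4

The source may hold more compounds than are shown below. What is called first, only, known or untested is meant among the compounds shown, and "the series" means these compounds.

Compound 1 `N#Cc1cnc(NCc2cnccc2C(F)(F)F)cc1N[C@H]1CC[C@@H](O)CC1` carries a 4-hydroxycyclohexyl group on a nitrogen on the shared core. In an assay on isolated protein for inhibition of protein kinase C delta type (Homo sapiens), read by TR-FRET, with a stated time of 2 h (on this read-out higher numbers stand for weaker inhibition and lower numbers for stronger inhibition), compound 1 gives 4500 nM. Compound 2 `N#Cc1cnc(NCc2cnccc2C(F)(F)F)cc1N[C@H]1CC[C@H](O)CC1` is its mirror image, and in this assay compound 2 gives 6500 nM. Compound 3 `CO[C@H]1CC[C@H](CNc2cc(NCc3cnccc3C(F)(F)F)ncc2C#N)CC1` carries a (4-methoxycyclohexyl)methyl group in that place instead. In this assay compound 3 reaches only a limit of the assay, > 10000 nM, so no number is known for it. Among the values shown, compound 3 is thus the one that stands only as a limit, as the limit of > 10000 nM in this assay, at which 1 of the 3 values shown sits, records. The step of an at least 2.2-fold higher number from compound 1 to compound 3 (0.34 log units; beyond the scatter) and the step of an at least 1.5-fold higher number from compound 2 to compound 3 (0.18 log units; that floor lies within the scatter) both run toward weaker inhibition when the hydroxyl group gives way to the methoxy group with its added methylene.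

Compound 4 `CC1(C)C[C@@H](Nc2cc(NCc3cnccc3C(F)(F)F)ncc2C#N)CC[C@H]1O` has not yet been measured. Relative to compound 3 the change is 4-hydroxy-3,3-dimethylcyclohexyl in place of (4-methoxycyclohexyl)methyl on a nitrogen on an aromatic ring. This restores a hydroxyl-bearing ring on the nitrogen, as in compound 1 and compound 2, while adding the dimethyl substitution. Since the measured steps point back toward compound 1 and compound 2, a step toward stronger inhibition in this assay is expected, an at least 2.0-fold lower number from compound 3 to compound 4 (0.30 log units; that floor lies within the scatter). Compound 4 is therefore estimated at 5000 nM, within a range from 1500 nM to 20000 nM.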

Compound 4, half-maximal inhibitory concentration: 2400 nM
Estimate against measurement, compound 4: 2.1-fold (0.32 log units) above; the range from low to high includes it.
By their numbers in this assay, from the lowest: compounds 4, 1 and 2 (each within the scatter of the next, the first and the last beyond it). At a limit, above all of these: compound 3.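

In this assay the change to 4-hydroxy-3,3-dimethylcyclohexyl gives an at least 4.1-fold lower number from compound 3 to compound 4 (0.61 log units; beyond the scatter) and so shows, with the same count of heavy atoms in the group that leaves and the group that enters, that a ring carrying a free hydroxyl on this nitrogen can read stronger than the (4-methoxycyclohexyl)methyl group. Compound 3 stands only at a limit of the assay, so the size of that step is a floor and not a measured gap. Set against the 4-hydroxycyclohexyl compounds, the new group gives a 2.7-fold lower number from compound 2 to compound 4 (0.43 log units; beyond the scatter) and also a 1.9-fold lower number from compound 1 to compound 4 (0.27 log units; within the scatter) and neither comparison shows the dimethyl substitution costing inhibition, though only the first of the two lies beyond the scatter.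

In the step from compound 3 to compound 4 the hydroxyl, the methylene and the dimethyl substitution all change at once, and the compounds shown do not separate their shares. Also open, on these data alone, is how an amine or a carboxylic acid in place of the hydroxyl on this ring would read in this assay on the shared core.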